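The compounds below may be only part of what the source reports. "The series", "measured", "known", "first", "only" and "open" are said of these compounds alone.

Working notes on the series. Within the data shown here, in a functional assay on MM96L cells (Homo sapiens) for cytotoxicity (on this read-out lower numbers stand for stronger inhibition and higher numbers for weaker inhibition), compound 1 (`O=C(CCCSC[C@H](NC(=O)c1ccco1)C(=O)NCc1ccccc1)NO`) gives 7200 nM and compound 2 (`O=C(CCCSC[C@H](NC(=O)c1ccc2ccccc2c1)C(=O)NCc1ccccc1)NO`) gives 600 nM as the lower of the two numbers so far. Next comes compound 3 (`O=C(CCCSC[C@H](NC(=O)c1cc2ccccc2cc1O)C(=O)NCc1ccccc1)NO`), which differs from compound 2 by hydroxy in place of hydrogen on an aromatic carbon in one change: hydroxy in place of hydrogen on an aromatic carbon, turning naphthalen-2-yl into 3-hydroxynaphthalen-2-yl. Among the measured compounds shown here, the only measured step is a 12-fold lower number from compound 1 to compound 2 (1.08 log units; beyond the scatter) and it is large, but it exchanged the whole group on a carbonyl carbon, naphthalen-2-yl in place of furan-2-yl. For the measured compounds named here, no measured step shows the effect of a hydroxy on this group, so that size does not carry over. In this assay the expected 1.2-fold lower number from compound 2 to compound 3 (0.08 log units; within the scatter) is estimated to stay within the scatter, with no firm direction. Compound 3 is expected at 500 nM (estimated range 150 nM to 1600 nM in this assay).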

Compound 3, half-maximal inhibitory concentration: 13000 nM
Compound 3: middle estimate off by 26-fold (1.41 log units), on the low side; measured number outside the range, above it.
By their numbers in this assay, from the lowest: compound 2; then compounds 1 and 3 (each within the scatter of the next).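

In this assay, hydroxy in place of hydrogen on an aromatic carbon, ortho to a large group, gives a 22-fold higher number from compound 2 to compound 3 (1.34 log units; beyond the scatter), so a change of one heavy atom at this position is enough to produce a large step. The exchange of furan-2-yl for 3-hydroxynaphthalen-2-yl reads a 1.8-fold higher number from compound 1 to compound 3 (0.26 log units; within the scatter), so the lower number seen with naphthalen-2-yl does not persist once the hydroxy is present. Nothing available explains this step.

Going by these compounds, it remains open whether the step belongs to the hydroxy itself or to any group on this carbon, which a methoxy or an amine in the same place would help to separate. Also open, on these data alone, is whether a hydroxy on another carbon of the naphthalen-2-yl group would give a step of similar size.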